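Swapping tert-butyl for benzyl in a shared core

The source may hold more compounds than are shown below. What is called first, only, known or untested is meant among the compounds shown, and "the series" means these compounds.

Compound 2 `CC(C)(C)OC(=O)N1CCN(C(=S)SCc2cn(Cc3ccc(Cl)cc3)nn2)CC1` carries a 4-chlorobenzyl group on an aromatic nitrogen of a shared core. In a functional assay on ECa-109 cells (Homo sapiens) for inhibition, read by MTT assay, with a stated time of 72 h (on this read-out higher numbers stand for weaker inhibition and lower numbers for stronger inhibition), compound 2 gives > 128000 nM, which is a limit of the assay rather than a number. Compound 1 `CC(C)(C)OC(=O)N1CCN(C(=S)SCc2cn(-c3ccccc3F)nn2)CC1`, with 2-fluorophenyl in that place, gives > 128000 nM in this assay, again a limit. Compound 3 `CC(C)(C)OC(=O)N1CCN(C(=S)SCc2cn(CCOc3ccc4ccc(=O)oc4c3)nn2)CC1` likewise gives > 128000 nM in this assay, also a limit. The step that the two limits leave unreadable from compound 1 to compound 2 therefore cannot be read. the limit of > 128000 nM in this assay, at which 3 of the 3 values shown sit, describes every measured value here.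

Compound 4 `O=C(OCc1ccccc1)N1CCN(C(=S)SCc2cn(Cc3ccc(Cl)cc3)nn2)CC1` differs from compound 2 at a single place: benzyl in place of tert-butyl on an oxygen next to a carbonyl group. Among the compounds with values here, no measured step touches this position, and the one measured step is unreadable, so there is no measured ground for expecting movement beyond the scatter in this assay. Compound 4 is expected to give 150000 nM, within 30000 nM to 600000 nM, in line with the limit reported for compound 2. The expected step that the limit leaves unreadable from compound 2 to compound 4 is thus essentially none, with a limit again the most likely report.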

Compound 4, half-maximal inhibitory concentration: > 128000 nM
Compound 4: only a limit was reported (the forecaster's own chance of this, stated with the estimate: 85%); the middle value does not contradict the limit.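

Compound 2 and compound 4 both report a limit of the assay rather than a number, so the step between them cannot be read: the limit of > 128000 nM in this assay, at which 4 of the 4 values shown sit. The compounds shown leave open whether any group on the aromatic nitrogen or on the oxygen next to a carbonyl group would give a real number in this assay at all.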